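Nitro for Trifluoromethyl on a Piperazine Urea

The source may report more compounds than this note shows. Statements on the series, on what has been measured and on what is new or still open speak of the compounds shown alone.

Of the compounds shown here, two have been measured in a functional assay on HEK293 cells for antagonist activity at transient receptor potential cation channel subfamily V member 1 (Rattus norvegicus); a higher number here means a weaker inhibitor, a lower number a stronger inhibitor. Compound 1, `CC(C)(C)c1ccc(NC(=S)N2CCN(c3ncccc3C(F)(F)F)CC2)cc1`, a thiourea, gives 441 nM in this assay. Compound 2, `O=C(Nc1ccc(C(F)(F)F)cc1)N1CCN(c2ncccc2Cl)CC1`, a urea, gives 81.4 nM in this assay, which is the lowest of the two numbers; the value of compound 1 lies above it by a margin beyond the scatter, but the two compounds differ in several places at once, so no single change can be credited.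

Compound 3, `O=C(Nc1ccc([N+](=O)[O-])cc1)N1CCN(c2ncccc2Cl)CC1`, is not yet measured. It differs from compound 2 in one place: nitro in place of trifluoromethyl on an aromatic carbon, on an aromatic carbon of a six-membered aromatic ring of carbon only, para to a large group. Among the compounds with values here, no measured pair in this small set isolates such a swap, so there is nothing to calibrate the step against.

The step from compound 2 to compound 3 is expected to be small, perhaps a mild rise in the number, as a 1.8-fold higher number from compound 2 to compound 3 (0.27 log units; within the scatter). Compound 3 is therefore estimated at 150 nM in this assay, within a range from 40 nM to 600 nM.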

Compound 3, half-maximal inhibitory concentration: > 25000 nM
Compound 3: a limit, no number; the forecaster's own chance of this, stated with the estimate: 5%; at least 160-fold (2.22 log units) between middle value and limit.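

Within the data shown here, the position para to a large group on the six-membered aromatic ring of carbon only proves far less forgiving than the earlier compounds could show: with the rest of compound 2 unchanged, nitro in place of trifluoromethyl gives an at least 300-fold higher number from compound 2 to compound 3 (2.48 log units; beyond the scatter). Among these compounds, this is the first step in the set that differs in one place, and it shows that this single substituent can decide whether the urea registers as an inhibitor at all in this assay. The reading of > 25000 nM for compound 3 is a limit of the assay and not a number, so the step has a lower bound but no measured size: the limit of > 25000 nM in this assay, at which 1 of the 3 values shown sits.

The compounds shown leave open how a nitrile, a methoxy group or an amine would read at this position, and so whether the loss is peculiar to nitro or extends to other replacements for trifluoromethyl. They also leave open whether nitro would have the same consequence on the thiourea of compound 1, which differs from compound 2 in several places.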